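Fluoro in place of isopropyl on a urea series

The source may hold more compounds than are shown below. What is called first, only, known or untested is meant among the compounds shown, and "the series" means these compounds.

Measured compounds:
Compound 1, `CCc1ccccc1NC(=O)N[C@@H](C)c1ccccc1`, 100%
Compound 2, `CC(C)c1cccc(NC(=O)N[C@H](C)c2ccccc2)c1`, 61%
Compound 3, `CC(C)c1cccc(NC(=O)N[C@@H](C)c2ccccc2)c1`, 84%

The three compounds share a urea core joined on one side to a substituted benzene ring and on the other to a saturated chain carbon that carries a phenyl ring. In an ADME assay on the whole organism with Oryza sativa as the target, tested at 1 uM (a lower number here means a stronger effect, a higher number a weaker effect of the compound at the concentration tested), compound 1 gives 100%, compound 2 gives 61% and compound 3 gives 84%. Within the data shown here, the only step measured between two compounds that differ in one place is a number 23 percentage points higher from compound 2 to compound 3 (beyond the scatter), and it rests on (the fact that compounds 2 and 3 differ only in the configuration as drawn). Compound 3 thus stands second of the three, with compound 1 somewhat higher and compound 2 lower.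

Compound 4, `C[C@H](NC(=O)Nc1cccc(F)c1)c1ccccc1`, differs from compound 3 by fluoro in place of isopropyl on an aromatic carbon. Among the measured compounds shown here, no measured step changes a group on this ring, so nothing here tells how large such a swap is in this assay. The measured step concerns configuration only and does not bear on it. Compound 4 is therefore expected to give 85%, within 55% to 100%, which means an expected step of a number 1 percentage points higher from compound 3 to compound 4 (within the scatter), not beyond the scatter.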

Compound 4, a percentage reported as activity, at one concentration (the size of the read-out at that concentration, not a potency): 94%
Beside the measured number, compound 4's estimate is 9 percentage points below it; the range from low to high includes it.
By their numbers in this assay, from the lowest: compound 2; then compounds 3, 4 and 1 (each within the scatter of the next, the first and the last beyond it).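

Set on this aromatic carbon, fluoro in place of isopropyl gives in this assay a number 10 percentage points higher from compound 3 to compound 4 (within the scatter) and so, for this pair, a group with 1 heavy atom cannot be told apart from one with 3 heavy atoms. Among these compounds, this is the first measured change of a group on this ring, and unlike the change of configuration between compound 2 and compound 3, it does not go beyond the scatter. Nothing at hand bears on why the swap behaves this way.

Still open, as far as these compounds go, is whether a methoxy, an amine or a carboxylic acid on this same carbon would shift the number beyond the scatter. Also open, from the compounds shown here alone, is whether the fluoro compound with the opposite configuration as drawn would differ from compound 4 as compound 2 differs from compound 3.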